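A few compounds are considered here, and "the series" means these few. Any claim that something is new, unique, unknown or untested is made for them only; others in the source may bear on it.

Compound 1 `CC1=CC[C@@H]([C@@](C)(O)CCCC(C)(C)NC(=S)N/N=C\c2ccccc2)CC1` gives 7720 nM in a functional assay on MCF7 cells (Homo sapiens) for cytotoxicity, read by sulforhodamine B assay; on this read-out higher numbers stand for weaker inhibition of growth and lower numbers for stronger inhibition of growth.
Compound 2 `CC1=CC[C@@H]([C@@](C)(O)CCCC(C)(C)NC(=S)N/N=C\c2ccc(C)cc2)CC1` gives 7230 nM in this assay.
Compound 3 `CC1=CC[C@@H]([C@@](C)(O)CCCC(C)(C)NC(=S)N/N=C\c2ccc(N(C)C)cc2)CC1` gives 14000 nM in this assay.

Among these three numbers, compound 3 stands highest, but the steps of a 1.8-fold higher number from compound 1 to compound 3 (0.26 log units; within the scatter) and a 1.9-fold higher number from compound 2 to compound 3 (0.29 log units; within the scatter) both lie within the scatter, as does a 1.1-fold lower number from compound 1 to compound 2 (0.03 log units; within the scatter), so no order among the three can be claimed. Compound 4 `CC1=CC[C@@H]([C@@](C)(O)CCCC(C)(C)NC(=S)N/N=C\c2ccccc2[N+](=O)[O-])CC1` differs from compound 3 by 2-nitrophenyl in place of 4-(dimethylamino)phenyl on a carbon with a double bond to nitrogen. The two steps into compound 3 are the ones that bear on this change, since each also swapped one group on the aromatic ring for another, and neither reached beyond the scatter. A further such swap is therefore expected to move this assay by no more than the scatter, in no set direction, an expected step of a 1.8-fold lower number from compound 3 to compound 4 (0.24 log units; within the scatter). Compound 4 is thus estimated at 8000 nM, with a range from 3000 nM to 25000 nM.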

Compound 4, concentration for 50% growth inhibition: 18600 nM
Beside the measured number, compound 4's estimate is 2.3-fold (0.37 log units) below it; low and high end bracket the measured number.
By their numbers in this assay, from the lowest: compounds 2, 1, 3 and 4 (each within the scatter of the next, the first and the last beyond it).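

In this assay, for the compounds shown here, the steps of a 2.4-fold higher number from compound 1 to compound 4 (0.38 log units; beyond the scatter) and a 2.6-fold higher number from compound 2 to compound 4 (0.41 log units; beyond the scatter) are the first to pass the scatter, both modest, so a change on this aromatic ring can weaken growth inhibition. Yet a 1.3-fold higher number from compound 3 to compound 4 (0.12 log units; within the scatter) stays within the scatter, leaving compound 3 not separable from any of the other three. No measurement shown gives a reason for this shift.

Open remains whether a chlorine or a carboxylic acid on this ring would move the number beyond the scatter towards stronger inhibition of growth.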